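Adding a cyano group to the aryl sulfonyl of compound 2

This account rests on a few compounds, and the source may have more. Where it says the series, first, only, none or still open, it means among the compounds named here.

Working from `N#Cc1ccc(O[C@H]2CN(S(=O)(=O)c3ccc(C(F)(F)F)cc3)C[C@@]2(O)CO)cc1F`, compound 2 gives 180 L/kg in an ADME assay on the whole organism (Rattus norvegicus, strain Sprague-Dawley) for pharmacokinetics, read by LC-MS, with a stated time of 30 min; on this read-out higher numbers stand for wider distribution into tissues and lower numbers for narrower distribution. Two other measured compounds frame it. Compound 1, `N#Cc1ccc(O[C@H]2CN(S(=O)(=O)c3ccc(Cl)cc3Cl)C[C@@]2(O)CO)cc1F`, gives 54 L/kg, and compound 3, `N#Cc1ccc(O[C@H]2CN(S(=O)(=O)c3ccc(Cl)cc3Cl)C[C@@]2(O)CN)cc1F`, gives 210 L/kg. Compound 2 and compound 3 lie within the scatter of each other, and compound 1 lies beyond the scatter of both.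

Compound 4, `N#Cc1ccc(O[C@H]2CN(S(=O)(=O)c3ccc(C(F)(F)F)cc3C#N)C[C@@]2(O)CO)cc1F`, is compound 2 with cyano in place of hydrogen on an aromatic carbon, ortho to a large group and meta to a trifluoromethyl group: cyano in place of hydrogen on an aromatic carbon.

For the measured compounds named here, no measured compound carries this cyano group, so no direct precedent exists. Going by the values given here, the nearest evidence is the one measured change on this aryl group, 4-(trifluoromethyl)phenyl in place of 2,4-dichlorophenyl, which is a 3.3-fold higher number from compound 1 to compound 2 (0.52 log units; beyond the scatter). That step is modest, and it shows that changes on this aryl group can move this assay. The other step, a 3.9-fold higher number from compound 1 to compound 3 (0.59 log units; beyond the scatter), is of similar size but lies on the chain at the far end of the molecule, so it bears only on the general scale of movement.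

A small downward step, a 1.6-fold lower number from compound 2 to compound 4 (0.21 log units; within the scatter), is expected, most likely within the scatter. Compound 4 is estimated at 110 L/kg, with an expected range of 35 L/kg to 320 L/kg.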

Compound 4, volume of distribution at steady state: 73 L/kg
For compound 4 the middle estimate is 1.5-fold (0.18 log units) above the measured one; measured number inside the range.
By their numbers in this assay, from the lowest: compounds 1 and 4 (each within the scatter of the next); then compounds 2 and 3 (each within the scatter of the next).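

In this assay, the aromatic carbon ortho to a large group and meta to a trifluoromethyl group is now shown to respond to a single added group: cyano in place of hydrogen gives a 2.5-fold lower number from compound 2 to compound 4 (0.39 log units; beyond the scatter) with the rest of compound 2 unchanged. The earlier aryl evidence, a 3.3-fold higher number from compound 1 to compound 2 (0.52 log units; beyond the scatter) as read, swapped one substitution pattern for another and could not be tied to one position, whereas this step isolates one carbon, and it runs downward, while both earlier steps ran upward. The data shown include no measurement that accounts for this drop in tissue distribution.

The compounds shown leave open whether the step belongs to cyano itself or to any group at this carbon, and fluoro, methyl, methoxy or a carboxylic acid there would separate those readings. Also open, on these data alone, is whether the step carries over to a compound with amino in place of hydroxy on the chain, as in compound 3, but with the 4-(trifluoromethyl)phenyl group of compound 2 retained.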